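From 4-methoxyphenyl to 4-nitrophenyl in this series

This account rests on a few compounds, and the source may have more. Where it says the series, first, only, none or still open, it means among the compounds named here.

Among the measured compounds shown here, only two compounds have numbers so far in a functional assay on RS4-11 cells (Homo sapiens) for inhibition, read by CCK-8 assay, with a stated time of 48 h, tested at 20 uM; on this read-out lower numbers stand for less inhibition of growth and higher numbers for more inhibition of growth at the one concentration tested. In this measurement compound 1 `COc1ccc(Cc2nnc(NC(=O)/C(C#N)=C/c3ccccc3OS(=O)(=O)c3ccc([N+](=O)[O-])cc3)s2)cc1` gives 70%, and compound 2 `COc1ccc(S(=O)(=O)Oc2ccccc2/C=C(\C#N)C(=O)Nc2nnc(Cc3cccc4ccccc34)s2)cc1` gives 78%. Compound 2 therefore stands within the scatter of compound 1, and the two cannot be ranked. For the measured compounds named here, no measured pair yet isolates a single structural change.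

Compound 3 `N#C/C(=C\c1ccccc1OS(=O)(=O)c1ccc([N+](=O)[O-])cc1)C(=O)Nc1nnc(Cc2cccc3ccccc23)s1` is still unmeasured. It arises from compound 2 through one change, nitro in place of methoxy on an aromatic carbon, para to a large group: nitro in place of methoxy on an aromatic carbon. Cut one bond further out, this reads as 4-methoxyphenyl to 4-nitrophenyl.

Going by the values given here, with no measured step to draw on, the only guide is that compound 1 at 70% and compound 2 at 78% lie within the scatter of each other. No shift beyond the scatter is therefore expected in this assay. The estimate amounts to a number 4 percentage points lower from compound 2 to compound 3 (within the scatter), a slight expected decrease in growth inhibition that stays inside the scatter. For compound 3 the estimated value is 74%, with an expected range from 60% to 88%.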

Compound 3, percent growth inhibition at one concentration: 58%
Beside the measured number, compound 3's estimate is 16 percentage points above it; the measured number lies below the stated range.
By their numbers in this assay, from the lowest: compound 3; then compounds 1 and 2 (each within the scatter of the next).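

In this assay the (4-methoxyphenyl)sulfonyl position proves sensitive to substitution: with naphthalen-1-yl held constant, nitro in place of methoxy on the aromatic carbon, para to a large group, gives a number 20 percentage points lower from compound 2 to compound 3 (beyond the scatter) as a modest step. The other end of the molecule also responds: with (4-nitrophenyl)sulfonyl held constant, naphthalen-1-yl in place of 4-methoxyphenyl on the saturated chain carbon gives a number 12 percentage points lower from compound 1 to compound 3 (beyond the scatter) as another modest step, which leaves compound 3, carrying both nitro and naphthalen-1-yl, lowest of the three and beyond the scatter of each of the others. No supporting data bear on the origin of either step.

The compounds shown leave open whether nitro in place of methoxy would give a step of similar size with 4-methoxyphenyl on the chain carbon, so the two steps cannot yet be treated as independent. Also open, as far as these compounds go, is how an amino group or a chlorine atom would behave on the same aromatic carbon, and whether either would follow methoxy or nitro.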